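The source may hold more compounds than are shown below. What is called first, only, known or untested is meant among the compounds shown, and "the series" means these compounds.

The record in a physicochemical assay for lipophilicity, at pH 7.4 (on this read-out lower numbers stand for lower lipophilicity and higher numbers for higher lipophilicity), is thin so far. Among the measured compounds shown here, compound 2 (`COc1ccc(NC(=O)[C@H]2CN(S(C)(=O)=O)C[C@@H]2C(=O)Nc2ccc(-n3ccccc3=O)cc2F)cc1`) gives 1.19 as the only number, so it cannot yet be placed high or low against any other compound. Compound 1 (`O=C(Nc1ccc(Cl)cc1)[C@H]1CN(Cc2ccncc2)C[C@@H]1C(=O)Nc1ccc(-n2ccccc2=O)cc1F`) has "not determined" (no result reported) as its entry and offers no comparison.

Compound 3 (`CS(=O)(=O)N1C[C@H](C(=O)Nc2ccc(Cl)c(F)c2)[C@@H](C(=O)Nc2ccc(-n3ccccc3=O)cc2F)C1`) has no reading yet. It differs from compound 2 in one place: 4-chloro-3-fluorophenyl in place of 4-methoxyphenyl on an amide-type nitrogen on an amide-type nitrogen, with the rest of the structure unchanged. In words, 4-chloro-3-fluorophenyl stands in place of 4-methoxyphenyl.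

For the measured compounds named here, no pair of measured compounds gives a step for this series, so nothing here calibrates the size of this change. Anchored on compound 2 at 1.19 and on the structural change alone, a rise in this assay beyond the usual scatter is expected. The estimated change is a number 0.86 log units higher from compound 2 to compound 3 (beyond the scatter) and it rests on that single anchor. For compound 3 the expected value is 2.05 and 1.6 to 2.5 is the estimated range.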

Compound 3, distribution coefficient: 2.37
Compound 3: the middle estimate sits 0.32 log units below what was measured; the measured number falls inside the stated range.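

Notes on the amide-type nitrogen: in this assay, 4-chloro-3-fluorophenyl in place of 4-methoxyphenyl gives a number 1.18 log units higher from compound 2 to compound 3 (beyond the scatter), the first measured step in the series, so this position clearly registers on this read-out. The step comes with no change in heavy-atom count, aromatic ring type, hydrogen-bond donors or net charge; the swap removes the oxygen with its hydrogen-bond acceptor and brings in fluorine and chlorine. No measurement at hand explains the size of this step.

The swap changes several features at once, so the shares of the methoxy loss, the chlorine and the fluorine cannot be separated until a phenyl ring bearing chlorine alone or fluorine alone is read in this assay. Also open, on these data alone, are where a phenyl ring carrying a carboxylic acid or a dimethylamino group would fall at this amide-type nitrogen, and whether the step holds when the rest of the structure differs from that shared by compound 2 and compound 3.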